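This account rests on a few compounds, and the source may have more. Where it says the series, first, only, none or still open, it means among the compounds named here.

Measured compounds:
compound 1, `CNC(=O)c1c(O)c2cccnc2n(-c2ccccc2)c1=O`: 21%
compound 2, `CCCCNC(=O)c1c(O)c2cccnc2n(-c2ccccc2)c1=O`: 20.4%
compound 3, `O=C(NC1CCN(Cc2ccccc2)CC1)c1c(O)c2cccnc2n(-c2ccccc2)c1=O`: 1.2%

In a functional assay on the whole organism for inhibition, with Rattus norvegicus as the target, read by cytopathic effect and paw edema, at a dose of 100 mg/kg by the oral route (on this read-out higher numbers stand for more inhibition at the one dose given (going by the name of the read-out) and lower numbers for less inhibition), compound 1 gives 21%. Compound 2 gives 20.4%, and these two numbers lie within the usual scatter of each other, so neither can be called stronger. Compound 3, which carries another substituent on the amide-type nitrogen, gives 1.2%, a number far below both.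

Compound 4, `O=C(NN1CCOCC1)c1c(O)c2cccnc2n(-c2ccccc2)c1=O`, is not yet measured. It differs from compound 1 in one place: morpholin-4-yl in place of methyl on an amide-type nitrogen. For the measured compounds named here, the only measured step that touches this spot is the one in which propyl replaces hydrogen on a saturated chain carbon bound to the amide-type nitrogen, a number 0.6 percentage points lower from compound 1 to compound 2 (within the scatter), a change of no consequence on this read-out. The drop seen for compound 3 shows, however, that a ring-bearing substituent on that nitrogen can lower the number sharply. The change to compound 4 sits between these two cases, so a moderate loss is expected, a number 7 percentage points lower from compound 1 to compound 4 (within the scatter), with wide uncertainty. Compound 4 is estimated at 14%, between 2% and 27%.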

Compound 4, a percentage reported as inhibition, in the whole organism at one dose (the size of the read-out at that dose, not a potency): -26.2%
Compound 4: the middle estimate sits 40.2 percentage points above what was measured; measured number outside the range, below it.
By their numbers in this assay, from the lowest: compound 4; then compound 3; then compounds 2 and 1 (each within the scatter of the next).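

In this assay, the group on the amide-type nitrogen matters far more than the two chains suggested: morpholin-4-yl in place of methyl gives a number 47.2 percentage points lower from compound 1 to compound 4 (beyond the scatter), and morpholin-4-yl in place of butyl gives a number 46.6 percentage points lower from compound 2 to compound 4 (beyond the scatter). Methyl and butyl had left the number unchanged within the scatter, and compound 3 had shown a low number at 1.2%, but compound 4 at -26.2% falls under zero, so a change at this one position can do more than take the number toward nothing. Nothing measured here explains why this ring has so large an effect on the number.

The compounds shown leave open which part of morpholin-4-yl goes with the drop, the ring as a whole, its oxygen, or its nitrogen bound directly to the amide-type nitrogen. Cyclohexyl, piperidin-1-yl and a two-carbon chain ending in morpholin-4-yl on the same nitrogen would each pull these apart, and it also remains open whether any other ring here would keep the number of the chains.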